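Ester Variation on a Shared Core: Cytotoxicity Expectation

The source may report more compounds than this note shows. Statements on the series, on what has been measured and on what is new or still open speak of the compounds shown alone.

Measured compounds:
compound 1, `N#CCC(=O)OCCc1c(-c2ccccc2Cl)c2cc(Cl)ccc2[nH]c1=O`, 100000 nM
compound 2, `CC(=O)OCC(=O)OCCc1c(-c2ccccc2Cl)c2cc(Cl)ccc2[nH]c1=O`, 100000 nM
compound 3, `O=C(CCC1CCCCC1)OCCc1c(-c2ccccc2Cl)c2cc(Cl)ccc2[nH]c1=O`, 160000 nM

The three measured compounds share one core and differ only in the group on the carbonyl carbon of the ester. In an ADME assay on HepG2 2.2.15 cells (Homo sapiens) for cytotoxicity (on this read-out lower numbers stand for higher toxicity in this test and higher numbers for lower toxicity in this test), compound 1 gives 100000 nM, compound 2 gives 100000 nM and compound 3 gives 160000 nM. The step of no change at the digits printed from compound 1 to compound 2 (within the scatter) and the steps of a 1.6-fold higher number from compound 1 to compound 3 (0.20 log units; within the scatter) and a 1.6-fold higher number from compound 2 to compound 3 (0.20 log units; within the scatter) all lie within the scatter, so compound 3 cannot be separated from the other two on these numbers: all three sit in the same narrow band of this assay.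

Compound 4, `COc1cccc(/C=C/C(=O)OCCc2c(-c3ccccc3Cl)c3cc(Cl)ccc3[nH]c2=O)c1`, is not yet measured. Relative to compound 3 the change is 2-(3-methoxyphenyl)ethenyl in place of 2-cyclohexylethyl on a carbonyl carbon. Going by the values given here, no measured step bears directly on an aromatic replacement of this kind; the steps that exist, a 1.6-fold higher number from compound 2 to compound 3 (0.20 log units; within the scatter) and a 1.6-fold higher number from compound 1 to compound 3 (0.20 log units; within the scatter), concern other groups at this position and were all within the scatter. On that basis no step beyond the scatter is expected for compound 4 in this assay, and the expected step is a 1.6-fold lower number from compound 3 to compound 4 (0.20 log units; within the scatter). Compound 4 is therefore estimated at 100000 nM, with a range from 50000 nM to 200000 nM.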

Compound 4, half-maximal cytotoxic concentration: > 1300000 nM
Compound 4: no number, only a limit; the forecaster's own chance of this, stated with the estimate: 30%; middle value at least 13-fold (1.11 log units) away from the limit.
By their numbers in this assay, from the lowest: compounds 1, 2 and 3 (each within the scatter of the next). At a limit, above all of these: compound 4.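

Compounds 1, 2 and 3 suggested that the group on the carbonyl carbon of the ester hardly mattered in this assay, since cyanomethyl, acetoxymethyl and 2-cyclohexylethyl could not be told apart there. Compound 4 shows that this place can move the read-out well beyond the scatter: with 2-(3-methoxyphenyl)ethenyl on the carbonyl carbon, the steps are large against two of the groups (an at least 13-fold higher number from compound 2 to compound 4 (1.11 log units; beyond the scatter); an at least 13-fold higher number from compound 1 to compound 4 (1.11 log units; beyond the scatter)) and at least modest against the one nearest in size (an at least 8.1-fold higher number from compound 3 to compound 4 (0.90 log units; beyond the scatter)), all towards lower toxicity in this test. The value of compound 4 is a limit and not a number: the limit of > 1300000 nM in this assay, at which 1 of the 4 values shown sits.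

The change from compound 3 to compound 4 brings in an aromatic ring, a double bond outside that ring and a methoxy group all at once, and the compounds shown do not separate these parts. A plain phenyl ring without the methoxy, a saturated chain in place of the ethenyl link, or an amine or carboxylic acid on the ring would each be needed to say which part goes with the step.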